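The compounds below may be only part of what the source reports. "The series", "measured", "known", "first", "only" and "open" are said of these compounds alone.

Measured so far:
compound 1 `O=C(CCCCCCc1ccccc1)c1ncc(-c2ccccc2C(=O)C(F)(F)F)o1`, 5000 nM
compound 2 `N#Cc1ccccc1-c1cnc(C(=O)CCCCCCc2ccccc2)o1`, 130 nM
compound 3 `O=C(CCCCCCc1ccccc1)c1ncc(-c2cccc(C(=O)C(F)(F)F)c2)o1`, 16 nM

In an assay (Rattus norvegicus) for inhibition of Fatty-acid amide hydrolase 1 (Homo sapiens) (a lower number here means a stronger inhibitor, a higher number a weaker inhibitor), compound 1 gives 5000 nM, and compound 2, which differs from it by cyano in place of (trifluoromethyl)carbonyl on an aromatic carbon, gives 130 nM, so that a 38-fold lower number from compound 1 to compound 2 (1.59 log units; beyond the scatter). Compound 3 carries the same atoms as compound 1 joined differently; how the two cores differ is not broken down here. In this assay compound 3 gives 16 nM, the lowest of the three numbers.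

Compound 4 `N#Cc1cccc(-c2cnc(C(=O)CCCCCCc3ccccc3)o2)c1` has not yet been measured. It differs from compound 3 by cyano in place of (trifluoromethyl)carbonyl on an aromatic carbon. This is the same kind of change as that from compound 1 to compound 2, but the place is not the same: there the cyano sits ortho to a large group, here meta to a large group. Because compound 3 already gives 16 nM, a step as large and in the same direction as a 38-fold lower number from compound 1 to compound 2 (1.59 log units; beyond the scatter) seems unlikely, and a modest rise in the number is expected, a 3.8-fold higher number from compound 3 to compound 4 (0.57 log units; beyond the scatter). Compound 4 is therefore estimated at 60 nM, most likely between 10 nM and 400 nM.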

Compound 4, inhibition constant: 15 nM
Beside the measured number, compound 4's estimate is 4.0-fold (0.60 log units) above it; the range from low to high includes it.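

In this assay, cyano in place of (trifluoromethyl)carbonyl gives a 1.1-fold lower number from compound 3 to compound 4 (0.03 log units; within the scatter), so on this core the swap leaves the number unchanged within the scatter, and the nitrile serves as well as the larger group. The same swap therefore does not carry a fixed effect from one core to the other: the same change on two cores in this assay, a 38-fold lower number (1.59 log units; beyond the scatter) from compound 1 to compound 2 and a 1.1-fold lower number (0.03 log units; within the scatter) from compound 3 to compound 4, 36-fold (1.56 log units) apart, beyond the scatter of two such steps. The move of the nitrile alone, 3-cyanophenyl in place of 2-cyanophenyl, gives an 8.7-fold lower number from compound 2 to compound 4 (0.94 log units; beyond the scatter), but these two cores show only that the outcome of the swap differs between them, not why it differs or what it would do on any further core.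

The compounds shown leave open whether another group at the same place on the aromatic ring, such as an amine or a carboxylic acid, would give a number close to those of compound 3 and compound 4. Also open, going by these compounds, is what a shorter or longer chain than the one shared by all four compounds would do to these numbers.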